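The source may report more compounds than this note shows. Statements on the series, on what has been measured and on what is new or still open speak of the compounds shown alone.

Series notes. In an assay on isolated protein for inhibition of ubiquitin carboxyl-terminal hydrolase 7 (Homo sapiens), with stated times of 30 min and 2 h (a lower number here means a stronger inhibitor, a higher number a weaker inhibitor), compound 1 `Cn1nc2c(=O)n(CC3(O)CCN(Cc4ccc(-c5n[nH]c(=O)o5)cc4Cl)CC3)cnc2c1-c1ccc(CN)cc1` gives 171 nM, and compound 2 `Cn1nc2c(=O)n(CC3(O)CCN(Cc4ccc(-n5ccnc5)cc4Cl)CC3)cnc2c1-c1ccc(CN)cc1` gives 228 nM. Among the measured compounds shown here, the one step between them, a 1.3-fold higher number from compound 1 to compound 2 (0.12 log units; within the scatter), exchanges one five-membered aromatic group for another and stays within the scatter. For the measured compounds named here, compound 2 therefore holds the higher of the two numbers so far, but its gap to compound 1 is not a real difference on these data.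

Compound 3 `Cn1nc2c(=O)n(CC3(O)CCN(Cc4ccc(C5CCCO5)cc4Cl)CC3)cnc2c1-c1ccc(CN)cc1` takes the same position further: oxolan-2-yl in place of 1H-imidazol-1-yl on an aromatic carbon. Going by the values given here, only the step from compound 1 to compound 2 bears on this change, and it was small; no step here yet replaces an aromatic group by a non-aromatic one. Compound 3 is expected to stay near compound 2, with a step of a 1.4-fold higher number from compound 2 to compound 3 (0.15 log units; within the scatter) in this assay that may not exceed the scatter. The estimate for compound 3 is 320 nM, within 120 nM to 850 nM.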

Compound 3, half-maximal inhibitory concentration: 3820 nM
Compound 3: the middle estimate sits 12-fold (1.08 log units) below what was measured; the measured number lies above the stated range.
By their numbers in this assay, from the lowest: compounds 1 and 2 (each within the scatter of the next); then compound 3.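

At this position, para to a large group and meta to a chloro group, the substituent is not freely interchangeable: in this assay the change from a five-membered aromatic ring to oxolan-2-yl gives a 17-fold higher number from compound 2 to compound 3 (1.22 log units; beyond the scatter) and a 22-fold higher number from compound 1 to compound 3 (1.35 log units; beyond the scatter), whereas the exchange between two aromatic rings stayed within the scatter. Oxolan-2-yl and 1H-imidazol-1-yl carry the same number of heavy atoms, so that count does not separate compound 2 from compound 3. Nothing available here accounts for the large step.

With a single non-aromatic group in the set, the loss of the aromatic ring cannot be separated from the change in hetero atoms. A phenyl ring, a cyclopentyl ring or a morpholine at this position would help to separate them.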